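Chain-extended acid on the difluoro aryl ether core

The source may hold more compounds than are shown below. What is called first, only, known or untested is meant among the compounds shown, and "the series" means these compounds.

Measured compounds in a functional assay on CHO cells for agonist activity at Free fatty acid receptor 1 (Homo sapiens), read by calcium flux; a lower number here means that less compound is needed, a higher number that more compound is needed for the effect:
- compound 1, `CO[C@H]1C[C@H](Oc2cc(F)c(F)c(-c3ccc4c(c3)CC[C@H](CCC(=O)O)O4)c2)C1`: > 100000 nM
- compound 2, `CO[C@H]1C[C@H](Oc2cc(F)c(F)c(-c3cc(F)c(OCCCC(=O)O)c(F)c3)c2)C1`: > 100000 nM
- compound 3, `CO[C@H]1C[C@H](Oc2ccc([N+](=O)[O-])c(-c3cc(F)c(OCCCC(=O)O)c(F)c3)c2)C1`: 29400 nM

Compound 2 reaches only a limit of this assay, not a number. Compound 1 likewise sits at a limit of this assay. Only compound 3 returns a number in this assay, namely 29400 nM. Compound 2 therefore stands at the weak end of what is shown, together with compound 1, and the evidence on the series is thin: the limit of > 100000 nM in this assay, at which 2 of the 3 values shown sit.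

Compound 4, `CO[C@H]1C[C@H](Oc2cc(F)c(F)c(-c3cc(F)c(OCCCCC(=O)O)c(F)c3)c2)C1`, is to be measured in this assay. It differs from compound 2 as follows: carboxymethyl in place of carboxy on a saturated chain carbon, three bonds along the chain from an oxygen on an aromatic ring. For the measured compounds named here, no step between two measured compounds covers this change, so there is no measured size to lean on. With compound 2 at a limit of this assay and only compound 3 giving a number, the expectation is a step no larger than the scatter, most likely another limit rather than a number.

The estimate for compound 4 in this assay is 100000 nM, within 30000 nM to 300000 nM, which would mean a step of a number no higher from compound 2 to compound 4 (the limit leaves the size open) from compound 2 to compound 4.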

Compound 4, half-maximal effective concentration: 68800 nM
Beside the measured number, compound 4's estimate is 1.5-fold (0.16 log units) above it; low and high end bracket the measured number.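

At this place, on a saturated chain carbon, three bonds along the chain from an oxygen on an aromatic ring, carboxymethyl in place of carboxy gives an at least 1.4-fold lower number from compound 2 to compound 4 (0.16 log units; that floor lies within the scatter) in this assay. For the compounds shown here, this is the first step that can be read at all, and it shows that this core can return a number in this assay without any change on the ring that carries the two adjacent-free fluorines' partner groups. Its true size stays open because compound 2 has only a limit: the limit of > 100000 nM in this assay, at which 2 of the 4 values shown sit.

Whether the chain trend continues is open, as a longer chain ending in the carboxylic acid is absent from the compounds shown. A branched chain, or a tetrazole in place of the carboxylic acid, would also test how much of this place tolerates change.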